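This account rests on a few compounds, and the source may have more. Where it says the series, first, only, none or still open, it means among the compounds named here.

In a functional assay on HepG2 cells (Homo sapiens) for antiproliferative activity, read by MTT assay, with a stated time of 48 h (a higher number here means that more compound is needed for the effect, a lower number that less compound is needed), three compounds sharing one core have been tested. Compound 1 `CC1=NN(S(=O)(=O)c2ccccc2)C(c2cc(Br)ccc2O)C1`, which carries phenyl on the sulfonyl sulfur, reads > 60000 nM, and this is a limit of the assay, not a number. Compound 2 `CC1=NN(S(=O)(=O)c2ccc(Cl)cc2)C(c2cc(Br)ccc2O)C1`, with chloro in place of one aromatic hydrogen, reads > 60000 nM, which is again a limit. Among the measured compounds shown here, compound 3 `CC1=NN(S(=O)(=O)c2ccc(Cl)cc2Cl)C(c2cc(Br)ccc2O)C1`, which carries 2,4-dichlorophenyl, gives 45200 nM, the only true number among the three.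

The next compound, compound 4 `CC1=NN(S(=O)(=O)c2ccccc2I)C(c2cc(Br)ccc2O)C1`, has not yet been measured. It differs from compound 3 by 2-iodophenyl in place of 2,4-dichlorophenyl on a sulfonyl sulfur, with 2-iodophenyl in place of 2,4-dichlorophenyl on a sulfonyl sulfur.

For the measured compounds named here, three measured steps concern this same aromatic group. Going by the values given here, the first chloro gave a step that the two limits leave unreadable from compound 1 to compound 2. The full change to 2,4-dichlorophenyl gave an at least 1.3-fold lower number from compound 1 to compound 3 (0.12 log units; that floor lies within the scatter), and the second chloro gave an at least 1.3-fold lower number from compound 2 to compound 3 (0.12 log units; that floor lies within the scatter). None of these compounds carries iodine, so these steps offer no measured size for the exchange itself. No step beyond the scatter is therefore expected in this assay, and the assay may report only a limit again. The estimated step is a 1.1-fold higher number from compound 3 to compound 4 (0.04 log units; within the scatter). For compound 4 the expected value is 50000 nM, with an estimated range of 20000 nM to 100000 nM.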

Compound 4, half-maximal effective concentration: > 60000 nM
Compound 4: a limit, no number; the forecaster's own chance of this, stated with the estimate: 45%; at least 1.2-fold (0.07 log units) between middle value and limit.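

Compound 4 gives a limit and not a number in this assay. On the sulfonyl sulfur, 2-iodophenyl in place of 2,4-dichlorophenyl gives an at least 1.3-fold higher number from compound 3 to compound 4 (0.12 log units; that floor lies within the scatter), so this exchange shows no readable step beyond the scatter, while the steps to compound 4 from compound 1 and from compound 2 cannot be read. The earlier compounds had tested only phenyl and chlorinated groups at this place; with 2-iodophenyl now included, 2,4-dichlorophenyl in compound 3 remains the only group here to give a true number, and phenyl, 4-chlorophenyl and 2-iodophenyl all share the same limit: the limit of > 60000 nM in this assay, at which 3 of the 4 values shown sit.

The compounds shown leave open how much compound would be needed for the effect with compound 1, compound 2 and compound 4, and therefore how large the real differences from compound 3 are. They also leave open whether a methoxy group or an amine on the aromatic ring attached to the sulfonyl sulfur would give a number clearly lower than that of compound 3.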